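The source may report more compounds than this note shows. Statements on the series, on what has been measured and on what is new or still open speak of the compounds shown alone.

Measured compounds:
compound 1, `CC1=CC[C@@H]([C@@](C)(O)CCCC(C)(C)NC=S)CC1`, > 100000 nM
compound 2, `CC1=CC[C@@H]([C@@](C)(O)CCCC(C)(C)NC(=S)N/N=C\c2ccc(C)cc2)CC1`, 45300 nM

In a functional assay on OVCAR-3 cells (Homo sapiens) for cytotoxicity, read by sulforhodamine B assay (a lower number here means that less compound is tolerated, a higher number that more compound is tolerated), compound 1 reaches only a limit, > 100000 nM. Among the compounds with values here, compound 2 gives 45300 nM in this assay, the only number among the two values shown. Compound 1 sits at the limit of > 100000 nM in this assay, at which 1 of the 2 values shown sits. Compound 3, `CC1=CC[C@@H]([C@@](C)(O)CCCC(C)(C)NC(=S)N/N=C\c2ccc(O)cc2)CC1`, differs from compound 2 by hydroxy in place of methyl on an aromatic carbon. Within the data shown here, no step between measured compounds is available to guide this change, so a shift of no more than the usual scatter in this assay is expected in either direction. Compound 3 is estimated at 40000 nM, with a range from 15000 nM to 110000 nM. The expected step of a 1.1-fold lower number from compound 2 to compound 3 (0.05 log units; within the scatter) lies within the scatter.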

Compound 3, concentration lethal to 50% of the cells: 54400 nM
For compound 3 the middle estimate is 1.4-fold (0.13 log units) below the measured one; measured number inside the range.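

In this assay, hydroxy in place of methyl on the aromatic carbon para to a large group gives a 1.2-fold higher number from compound 2 to compound 3 (0.08 log units; within the scatter). Within the data shown here, this is the first step read at this position, and it shows that 4-methylphenyl and 4-hydroxyphenyl stand within the scatter of each other, although the hydroxy brings a hydrogen-bond donor and acceptor that the methyl lacks. Nothing measured here gives a cause for this result. From the compounds shown here alone, whether an amine, a methoxy group or a fluorine on this carbon would also stay within the scatter remains open. So does the effect of a hydroxy on another carbon of this ring.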